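Piperazinylmethyl in Place of a Tolyl Ring

The compounds below may be only part of what the source reports. "The series", "measured", "known", "first", "only" and "open" are said of these compounds alone.

Compound 2 `Cc1ccc(C(=O)N2N=C(c3cc4ccccc4oc3=O)CC2c2ccccc2)cc1` was tested in a functional assay on MGC-803 cells (Homo sapiens) for cytotoxicity, read by MTT assay, with a stated time of 48 h (on this read-out higher numbers stand for weaker inhibition and lower numbers for stronger inhibition), and gave 31300 nM, the higher of the two numbers recorded; compound 1 `CC1=NN(C(=O)CN2CCN(C(=O)OC(C)(C)C)CC2)C(c2ccccc2O)C1` gave 17600 nM, which lies within the scatter of that result, so no order between them can be claimed. Compound 3 `CN1CCN(CC(=O)N2N=C(c3cc4ccccc4oc3=O)CC2c2ccccc2)CC1` differs from compound 2 in one place: (4-methylpiperazin-1-yl)methyl in place of 4-methylphenyl on a carbonyl carbon. No comparable change has been measured here, though compound 1 also carries a (4-methylpiperazin-1-yl)methyl on a carbonyl carbon. The step of a 1.6-fold lower number from compound 2 to compound 3 (0.19 log units; within the scatter) is expected to remain within the scatter. Compound 3 is estimated at 20000 nM, with a range from 6000 nM to 60000 nM.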

Compound 3, half-maximal inhibitory concentration: 46100 nM
Compound 3: the middle estimate sits 2.3-fold (0.36 log units) below what was measured; low and high end bracket the measured number.
By their numbers in this assay, from the lowest: compounds 1, 2 and 3 (each within the scatter of the next, the first and the last beyond it).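

In this assay, (4-methylpiperazin-1-yl)methyl in place of 4-methylphenyl on a carbonyl carbon gives a 1.5-fold higher number from compound 2 to compound 3 (0.17 log units; within the scatter), the first step read at this position. A non-aromatic ring with two hetero atoms can thus stand where an aromatic carbon ring stood without a change that can be told from the scatter. No independent data bear on why this is so. As far as these compounds go, it remains open whether a primary amine or a carboxylic acid on the same carbonyl carbon would move the number beyond the scatter.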